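From Methoxy to Chloro on Compound 3

The compounds below may be only part of what the source reports. "The series", "measured", "known", "first", "only" and "open" are said of these compounds alone.

In a functional assay on MCF7 cells (Homo sapiens) for cytotoxicity, read by MTT assay, with a stated time of 48 h (on this read-out lower numbers stand for stronger inhibition and higher numbers for weaker inhibition), compound 1 `COc1ccc(-c2nnc(COc3ccc(C#N)cc3OC)o2)cc1` gives 11100 nM. Compound 2 `N#Cc1ccc(OCc2nnc(-c3ccccc3)o2)cc1F` reaches only a limit of the assay, > 50000 nM. Compound 3 `COc1ccc(-c2nnc(COc3ccc(-c4nnco4)cc3)o2)cc1` gives 31200 nM, the higher of the two actual numbers, and its gap to compound 1 lies beyond the scatter. Compound 4 `Clc1ccc(-c2nnc(COc3ccc(-c4nnco4)cc3)o2)cc1` carries chloro in place of methoxy on an aromatic carbon, para to a large group (chloro in place of methoxy on an aromatic carbon). Among the measured compounds shown here, no measured pair shows this swap, so the size of its effect has no direct guide. The expected result in this assay is no change beyond the scatter, an estimated 1.2-fold lower number from compound 3 to compound 4 (0.10 log units; within the scatter). For compound 4 the estimated value is 25000 nM, with an expected range of 9000 nM to 50000 nM.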

Compound 4, half-maximal inhibitory concentration: 45200 nM
For compound 4 the middle estimate is 1.8-fold (0.26 log units) below the measured one; measured number inside the range.
By their numbers in this assay, from the lowest: compound 1; then compounds 3 and 4 (each within the scatter of the next). At a limit, above all of these: compound 2.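

Swapping 4-methoxyphenyl for 4-chlorophenyl gives the first direct pair in this series, and it reads a 1.4-fold higher number from compound 3 to compound 4 (0.16 log units; within the scatter). At this place, then, a chlorine atom can stand in for the carbon and oxygen of methoxy with no change that can be told from the scatter. Both numbers lie close to the top of what the assay can read: the limit of > 50000 nM in this assay, at which 1 of the 4 values shown sits.

Going by these compounds, whether an amine or a carboxylic acid at this place would move the number beyond the scatter stays open. So does whether chloro would behave the same way on the core of compound 1.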